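From ethoxycarbonyl to isopropoxycarbonyl: what to expect of compound 3

This account rests on a few compounds, and the source may have more. Where it says the series, first, only, none or still open, it means among the compounds named here.

In a functional assay on the whole organism for antagonist activity, with Mus musculus as the target, in the maximal electroshock model (on this read-out lower numbers stand for an effect already at smaller amounts and higher numbers for an effect only at larger amounts of compound), compound 2 (`CCOC(=O)NC1=NC(c2ccccc2Cl)CN1C`) gives 28 mg/kg as its measured dose. Compound 1 (`CC(C)OC(=O)NC1=NC(c2ccccc2F)CN1C`) gives 23 mg/kg on the same read-out. These two numbers lie within the scatter of each other, so compound 2 stands level with compound 1.

Compound 3 (`CC(C)OC(=O)NC1=NC(c2ccccc2Cl)CN1C`) is still unmeasured. It differs from compound 2 in one place (methyl in place of hydrogen on a saturated chain carbon bound to an oxygen next to a carbonyl group and a saturated chain carbon): methyl takes the place of hydrogen on a saturated chain carbon bound to an oxygen next to a carbonyl group and a saturated chain carbon. Ethoxycarbonyl thus becomes isopropoxycarbonyl. Within the data shown here, no two measured compounds differ in just one place, so the data show no direct step to lean on. Compound 1 also carries isopropoxycarbonyl, and its 23 mg/kg within the scatter of compound 2 suggests only a small effect. The expected change (a 1.1-fold lower number from compound 2 to compound 3 (0.05 log units; within the scatter)) stays within the scatter, with no clear direction. In this assay compound 3 is expected to give 25 mg/kg as a central estimate, within a range from 12 mg/kg to 50 mg/kg at its outer ends.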

Compound 3, dose for half-maximal effect: 35 mg/kg
Beside the measured number, compound 3's estimate is 1.4-fold (0.15 log units) below it; the range from low to high includes it.
By their numbers in this assay, from the lowest: compounds 1, 2 and 3 (each within the scatter of the next).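

In this assay, among these compounds, methyl in place of hydrogen on the saturated chain carbon bound to an oxygen gives a 1.3-fold higher number from compound 2 to compound 3 (0.10 log units; within the scatter) as the first direct reading of this change, so ethoxycarbonyl and isopropoxycarbonyl cannot be told apart on this read-out. The second single change, chloro in place of fluoro on an aromatic carbon, gives a 1.5-fold higher number from compound 1 to compound 3 (0.18 log units; within the scatter) and also stays inside the normal variation between repeat measurements, so neither change has a clear effect on the dose needed. No supporting data bear on why both changes leave the number within that variation.

Among the compounds shown here, with only two small groups compared at the chain carbon, it remains open whether a longer chain, such as the one in butoxycarbonyl, would produce a step beyond the scatter. From the compounds shown here alone, on the aromatic carbon, the comparison covers only chloro and fluoro, so it also remains open how a different group, such as methoxy or nitrile, would change the dose needed in this assay when placed there.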